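The source may hold more compounds than are shown below. What is called first, only, known or untested is meant among the compounds shown, and "the series" means these compounds.

Among the measured compounds shown here, compound 1 `COc1cc(N)c(Cl)cc1NC(=O)C1CCN(Cc2ccc(F)cc2)CC1` gives 0.6 mg/kg in a functional assay on the whole organism for antagonist activity, with Mus musculus as the target (a lower number here means that less compound is needed, a higher number that more compound is needed for the effect), and it holds the only number among the three values shown. The other two values shown are limits. Compound 2 `COc1cc(N)c(Cl)cc1NC(=O)C1CCN(CC2CCCC2)CC1` reaches only a limit, > 10 mg/kg. Compound 3 `CCCCCCN1CCC(C(=O)Nc2cc(Cl)c(N)cc2OC)CC1` likewise reaches only a limit, > 10 mg/kg. Both replacements of the 4-fluorophenyl group cost dearly: an at least 16-fold higher number from compound 1 to compound 2 (1.22 log units; beyond the scatter) and an at least 16-fold higher number from compound 1 to compound 3 (1.22 log units; beyond the scatter), with both results resting at the limit of > 10 mg/kg in this assay, at which 2 of the 3 values shown sit. Compound 4 `CCC(CC)CN1CCC(C(=O)Nc2cc(Cl)c(N)cc2OC)CC1` carries a change of the same kind at the same place, (pentan-3-yl in place of 4-fluorophenyl on a saturated chain carbon bound to an amine nitrogen in a ring). Since the cyclopentyl and pentyl replacements both gave large losses, a large loss is expected here too, a 17-fold higher number from compound 1 to compound 4 (1.22 log units; beyond the scatter), most likely ending at a limit. Compound 4 is therefore estimated at 10 mg/kg, within 3 mg/kg to 30 mg/kg.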

Compound 4, dose for half-maximal effect: > 10 mg/kg
Compound 4: a limit, no number; the forecaster's own chance of this, stated with the estimate: 70%; the middle value sits exactly at the limit.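

The branched pentan-3-yl group fares no better here than cyclopentyl or pentyl, with an at least 16-fold higher number from compound 1 to compound 4 (1.22 log units; beyond the scatter) on replacing 4-fluorophenyl. A saturated group without a ring, branched at this place, therefore also fails to retain the activity of compound 1, which alone gives a number rather than a limit: the limit of > 10 mg/kg in this assay, at which 3 of the 4 values shown sit. The steps among compound 2, compound 3 and compound 4 cannot be read, as all three values are limits.

On these data alone, whether a plain phenyl or a pyridyl ring at this place would retain that activity stays open. The compounds shown therefore do not separate the part of the aromatic ring from that of the fluorine.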